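From Nitro to Methoxy on a Shared Core

This account rests on a few compounds, and the source may have more. Where it says the series, first, only, none or still open, it means among the compounds named here.

Of the compounds shown here, three have been measured in a functional assay on HCT-116 cells (Homo sapiens) for inhibition, read by sulforhodamine B assay, with a stated time of 72 h; a higher number here means a weaker inhibitor, a lower number a stronger inhibitor: compound 1 `Cc1ccc(C2=Nn3c(nnc3C(C)c3ccc(CC(C)C)cc3)SC2)cc1` gives 4000 nM, compound 2 `COc1ccc2cc(C(C)c3nnc4n3N=C(c3ccc([N+](=O)[O-])cc3)CS4)ccc2c1` gives 15100 nM, and compound 3 `CC(C)Cc1ccc(C(C)c2n[nH]c(=S)n2N)cc1` gives 27400 nM. Compound 2 thus stands within the scatter of compound 3 and beyond the scatter from compound 1, whose number is lower. Compound 4 `COc1ccc(C2=Nn3c(nnc3C(C)c3ccc4cc(OC)ccc4c3)SC2)cc1` puts methoxy in place of nitro on an aromatic carbon, para to a large group: methoxy in place of nitro on an aromatic carbon. Among the compounds with values here, no measured pair differs in one place, so nothing measured sizes this change. Only a small move toward lower numbers is expected in this assay, probably none beyond the scatter. The expected step is a 1.4-fold lower number from compound 2 to compound 4 (0.14 log units; within the scatter). For compound 4 the estimated value is 11000 nM, within a range of 4000 nM to 30000 nM.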

Compound 4, half-maximal inhibitory concentration: 6500 nM
Compound 4: the middle estimate sits 1.7-fold (0.23 log units) above what was measured; the measured number falls inside the stated range.
By their numbers in this assay, from the lowest: compounds 1 and 4 (each within the scatter of the next); then compounds 2 and 3 (each within the scatter of the next).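

In this assay, methoxy in place of nitro on an aromatic carbon, para to a large group, gives a 2.3-fold lower number from compound 2 to compound 4 (0.37 log units; beyond the scatter) and so provides the first measured pair differing in one place. The number at this position therefore moves with the change from 4-nitrophenyl to 4-methoxyphenyl, though the step is modest. Nothing available explains this step.

The compounds shown leave open whether an amine or a chlorine at this position would give a lower or a higher number. They also leave open whether the same step would appear on the core of compound 1.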